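Oxime Oxygen Substituent: From Isoxazolylmethyl to Dimethylcarbamoyl

The source may report more compounds than this note shows. Statements on the series, on what has been measured and on what is new or still open speak of the compounds shown alone.

Compound 1, `COC(=O)c1cc(CO/N=C(\C)c2ccc(Sc3cc(F)cc(C4CCOCC4)c3)cc2)on1`: 100 nM
Compound 2, `CO[C@]1(c2cnc(S(=O)(=O)c3ccc(/C(C)=N/O)cc3)s2)CCO[C@@H](C)C1`: 320 nM

In a functional assay (blood) for inhibition, with Homo sapiens as the target (on this read-out lower numbers stand for stronger inhibition and higher numbers for weaker inhibition), compound 1 gives 100 nM, the lower of the two numbers, while compound 2 gives 320 nM, a gap that lies beyond the usual scatter. Compound 3, `C/C(=N\OC(=O)N(C)C)c1ccc(Sc2cc(F)cc(C3CCOCC3)c2)cc1`, differs from compound 1 in one place: dimethylcarbamoyl in place of (3-(methoxycarbonyl)-1,2-oxazol-5-yl)methyl on an oxygen. Within the data shown here, no measured pair shows this change, so the step is unanchored. The step of a 2.0-fold higher number from compound 1 to compound 3 (0.30 log units; within the scatter) is expected to be small, leaning toward a higher number but not clearly beyond the scatter. Compound 3 is therefore expected to give 200 nM in this assay. For compound 3 the expected range runs from 60 nM to 700 nM.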

Compound 3, half-maximal inhibitory concentration: 2610 nM
Estimate against measurement, compound 3: 13-fold (1.12 log units) below; the measured number lies above the stated range.
By their numbers in this assay, from the lowest: compound 1; then compound 2; then compound 3.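

In this assay the exchange of (3-(methoxycarbonyl)-1,2-oxazol-5-yl)methyl for dimethylcarbamoyl gives a 26-fold higher number from compound 1 to compound 3 (1.42 log units; beyond the scatter) and so marks a large step toward weaker inhibition. The group on this oxygen, whose other neighbour is a double-bonded nitrogen, therefore strongly affects inhibition on the core of compound 1. Nothing available bears on the reason for this step.

Left open is whether the step follows the loss of the five-membered aromatic ring or the arrival of the carbamoyl group. A benzyl group or a plain methyl on the same oxygen would separate the two.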